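Moving the Trifluoromethyl Group Along the Phenethyl Arm

A few compounds are considered here, and "the series" means these few. Any claim that something is new, unique, unknown or untested is made for them only; others in the source may bear on it.

Compound 1: `CCc1nc(Cl)c2n1CCN([C@@H](C(=O)NC)c1ccccc1)[C@H]2CCc1cccc(C(F)(F)F)c1` gives 10 nM in a functional assay on CHO cells for antagonist activity at Orexin receptor type 2 (Homo sapiens), read by FLIPR and calcium flux; a higher number here means a weaker inhibitor, a lower number a stronger inhibitor.
Compound 2: `CCc1nc(Cl)c2n1CCN([C@@H](C(=O)NC)c1ccccc1)[C@H]2COc1ccc(C(F)(F)F)cc1` gives 9 nM in this assay.
Compound 3: `CNC(=O)[C@@H](c1ccccc1)N1CCn2c(C3CC3)nc(Cl)c2[C@@H]1CCc1ccc(C(F)(F)F)cc1` gives 9 nM in this assay.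

Compound 3 sits level with compound 2, and all three measured numbers lie within the scatter of one another, so none can be called stronger or weaker. Compound 4 is `CNC(=O)[C@@H](c1ccccc1)N1CCn2c(C3CC3)nc(Cl)c2[C@@H]1CCc1cccc(C(F)(F)F)c1`; it differs from compound 3 by 3-(trifluoromethyl)phenyl in place of 4-(trifluoromethyl)phenyl on a saturated chain carbon, two bonds along the chain from a saturated ring carbon. For the measured compounds named here, no measured step covers exactly this change. Going by the values given here, the one measured step, a 1.1-fold lower number from compound 1 to compound 2 (0.05 log units; within the scatter), moved the trifluoromethyl group and also swapped the linker, and it stayed within the scatter. Compound 1 carries the 3-(trifluoromethyl)phenyl group on the chain with a different core and shows a number close to that of compound 3. The expectation for compound 4 is therefore no change beyond the scatter, a 1.1-fold higher number from compound 3 to compound 4 (0.05 log units; within the scatter). Compound 4 is estimated at 10 nM, with a range of 4 nM to 25 nM.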

Compound 4, half-maximal inhibitory concentration: 7 nM
Compound 4: the middle estimate sits 1.4-fold (0.15 log units) above what was measured; measured number inside the range.
By their numbers in this assay, from the lowest: compounds 4, 2, 3 and 1 (each within the scatter of the next).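

With the core held fixed, this assay now reads the 3-(trifluoromethyl)phenyl for 4-(trifluoromethyl)phenyl change on its own, and the two groups cannot be told apart at this place on the chain (a 1.3-fold lower number from compound 3 to compound 4 (0.11 log units; within the scatter)). Cyclopropyl in place of ethyl on an aromatic carbon, also seen alone for the first time, stays equally unresolved (a 1.4-fold lower number from compound 1 to compound 4 (0.15 log units; within the scatter)). No supporting measurement offers an explanation for either result. Still open, going by these compounds, is whether the number would hold with a nitrile or an amine in place of trifluoromethyl, or with a longer chain.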